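The source may report more compounds than this note shows. Statements on the series, on what has been measured and on what is new or still open speak of the compounds shown alone.

Compound 3 `Cc1nsc(-c2ccc(N3CCN(c4cc(C(F)(F)F)cc(C(F)(F)F)c4)CC3)nn2)n1` stands at < 0.1 nM in a functional assay (aorta) for inhibition, with Rattus norvegicus as the target (a higher number here means a weaker inhibitor, a lower number a stronger inhibitor), and this is a limit of the assay, not a number. The move to compound 4 `FC(F)(F)c1cc(N2CCN(c3ccc(-c4ncns4)nn3)CC2)cc(C(F)(F)F)c1` is hydrogen in place of methyl on an aromatic carbon: 3-methyl-1,2,4-thiadiazol-5-yl to 1,2,4-thiadiazol-5-yl. The reverse change has been measured, with compound 1 `FC(F)(F)c1cccc(N2CCN(c3ccc(-c4ncns4)nn3)CC2)c1` at 70 nM and compound 2 `Cc1nsc(-c2ccc(N3CCN(c4cccc(C(F)(F)F)c4)CC3)nn2)n1` at 0.3 nM. That was a 230-fold lower number from compound 1 to compound 2 (2.37 log units; beyond the scatter). The trifluoromethyl step was an at least 3.0-fold lower number from compound 2 to compound 3 (0.47 log units; beyond the scatter), so compound 4 is expected to come in somewhat lower than compound 1. Reversing a 230-fold lower number from compound 1 to compound 2 (2.37 log units; beyond the scatter) points to a large expected rise in this assay. The expected move is an at least 150-fold higher number from compound 3 to compound 4 (2.17 log units; beyond the scatter). For compound 4 the estimate is 15 nM, with an expected range of 3 nM to 60 nM.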

Compound 4, half-maximal inhibitory concentration: < 1 nM
Compound 4 ended at the assay's limit; the forecaster's own chance of this, stated with the estimate: 2%; at least 15-fold (1.17 log units) between middle value and limit.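

Compound 4 gives < 1 nM in this assay, a limit of the assay, so hydrogen on this carbon, between two ring nitrogen atoms, still allows strong inhibition with the second trifluoromethyl present. Without the methyl, adding that trifluoromethyl gives an at least 70-fold lower number from compound 1 to compound 4 (1.84 log units; beyond the scatter). The step from methyl to hydrogen with both trifluoromethyl groups present cannot be read, and the size of the trifluoromethyl change on each core stays unsettled: the same change on two cores in this assay, an at least 3.0-fold lower number (0.47 log units; beyond the scatter) from compound 2 to compound 3 and an at least 70-fold lower number (1.84 log units; beyond the scatter) from compound 1 to compound 4; the limit leaves it open whether they differ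

As far as these compounds go, what the methyl contributes alongside both trifluoromethyl groups remains open. So does the outcome of an amine or a methoxy group on this carbon.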